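Hydroxy in Place of Cyano on a Shared Core

The source may hold more compounds than are shown below. What is called first, only, known or untested is meant among the compounds shown, and "the series" means these compounds.

Compound 1, `Nc1nc(-c2cccc(O)c2)nc2sc(-c3ccccc3)nc12`, in a functional assay on CHO cells for antagonist activity at adenosine receptor A2b (Homo sapiens), read by cAMP accumulation, with a stated time of 10 min (a lower number here means a stronger inhibitor, a higher number a weaker inhibitor), gives > 30000 nM, which is a limit of the assay and not a number.
Compound 2, `Nc1nc(-c2ccccc2)nc2sc(-c3ccco3)nc12`, in this assay gives > 30000 nM, again a limit of the assay.
Compound 3, `N#Cc1cccc(-c2nc(N)c3nc(-c4ccco4)sc3n2)c1`, in this assay gives > 30000 nM, also a limit of the assay.

Compound 3 therefore stands at the limit, and so do the other two measured compounds: the limit of > 30000 nM in this assay, at which 3 of the 3 values shown sit. Within the data shown here, the one measured step between structures that differ in a single place, a step that the two limits leave unreadable from compound 2 to compound 3, runs between two limits, so its size cannot be read.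

Compound 4, `Nc1nc(-c2cccc(O)c2)nc2sc(-c3ccco3)nc12`, differs from compound 3 by hydroxy in place of cyano on an aromatic carbon. Among the measured compounds shown here, no measured step bears directly on this change. Compound 1, which also carries the hydroxy group on its six-membered aromatic ring, likewise reaches only the limit in this assay. For the measured compounds named here, with every value shown sitting at the limit, the data give no footing for a step of any readable size in either direction. The step of a number no higher from compound 3 to compound 4 (the limit leaves the size open) is thus expected to stay within the scatter, and compound 4 is expected most likely to give only a limit again. Compound 4 is estimated at 30000 nM, within a range of 10000 nM to 100000 nM.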

Compound 4, half-maximal inhibitory concentration: > 30000 nM
Compound 4 ended at the assay's limit; the forecaster's own chance of this, stated with the estimate: 80%; the middle value lies on the limit itself.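

No step from compound 1, compound 2 or compound 3 to compound 4 can be read, as each runs between two limits of the assay: the limit of > 30000 nM in this assay, at which 4 of the 4 values shown sit.

The compounds shown leave open whether any of these groups on the shared core changes inhibition in this assay, and how strong any such inhibition would be.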